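Triazole substituent series: decyl chain in place of aryl

The compounds below may be only part of what the source reports. "The series", "measured", "known", "first", "only" and "open" are said of these compounds alone.

Compound 3 `Cc1ccc(-c2cn(C[C@H](O)[C@H]3OC(=O)C(OCc4ccccc4)=C3OCc3ccccc3)nn2)cc1` carries a 4-methylphenyl on the triazole carbon of the shared core. In a functional assay on HeLa cells (Homo sapiens) for antiproliferative activity, read by MTT assay, with a stated time of 72 h (a higher number here means a weaker inhibitor, a lower number a stronger inhibitor), compound 3 gives 25500 nM. Its nearest neighbour is compound 2 `O=C1O[C@H]([C@@H](O)Cn2cc(CNS(=O)(=O)c3ccc(F)cc3)nn2)C(OCc2ccccc2)=C1OCc1ccccc1`, which gives 25000 nM; the step of a 1.0-fold higher number from compound 2 to compound 3 (0.01 log units; within the scatter). Compound 1 `Cc1ccc(S(=O)(=O)NCc2cn(C[C@H](O)[C@H]3OC(=O)C(OCc4ccccc4)=C3OCc3ccccc3)nn2)cc1` gives 14400 nM, and the step of a 1.8-fold higher number from compound 1 to compound 3 (0.25 log units; within the scatter). Compound 3 therefore sits with compound 1 and compound 2 on the numbers shown, none of the three separated from another beyond the scatter.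

Compound 4 `CCCCCCCCCCc1cn(C[C@H](O)[C@H]2OC(=O)C(OCc3ccccc3)=C2OCc2ccccc2)nn1` differs from compound 3 by decyl in place of 4-methylphenyl on an aromatic carbon.

Among the compounds with values here, no measured step swaps an aryl for an alkyl chain at this position, so none bears directly on the change. What is known is that varying the group on this aromatic carbon, from 4-methylphenyl to (((4-methylphenyl)sulfonyl)amino)methyl or (((4-fluorophenyl)sulfonyl)amino)methyl, moved the number only within the scatter, as a 1.8-fold higher number from compound 1 to compound 3 (0.25 log units; within the scatter) and a 1.0-fold higher number from compound 2 to compound 3 (0.01 log units; within the scatter) show. The expectation for decyl is therefore no step beyond the scatter in this assay, with a wide range either way. Compound 4 is expected to give 22000 nM, between 7000 nM and 70000 nM; the expected step is a 1.2-fold lower number from compound 3 to compound 4 (0.06 log units; within the scatter).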

Compound 4, half-maximal inhibitory concentration: 22900 nM
Compound 4: the middle estimate sits 1.0-fold (0.02 log units) below what was measured; low and high end bracket the measured number.
By their numbers in this assay, from the lowest: compounds 1, 4, 2 and 3 (each within the scatter of the next).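

Within the data shown here, the first swap of an aryl for an open chain at this aromatic carbon leaves the number within the scatter in this assay (a 1.1-fold lower number from compound 3 to compound 4 (0.05 log units; within the scatter)), so the six-membered aromatic ring of 4-methylphenyl is not required for activity of this size. Decyl, with no ring and no hydrogen-bond donors or acceptors, also stays within the scatter of the two compounds carrying a sulfonylamino group on the chain carbon (a 1.1-fold lower number from compound 2 to compound 4 (0.04 log units; within the scatter); a 1.6-fold higher number from compound 1 to compound 4 (0.20 log units; within the scatter)), which extends the flat response at this position to a purely hydrocarbon chain. No measured evidence accounts for this flat response.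

Still open, from the compounds shown here alone, is whether the response stays flat with a shorter chain such as butyl, a longer chain such as hexadecyl, or a decyl chain ending in an amine or a carboxylic acid. Also open, going by these compounds, is whether any group on this aromatic carbon, or a change to the benzyloxy groups of the shared core, can move the number beyond the scatter.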